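Replacing a Sulfonyl Pair with a Small Amine

The compounds below may be only part of what the source reports. "The series", "measured", "known", "first", "only" and "open" are said of these compounds alone.

Of the compounds shown here, two have been measured in a functional assay for antagonist activity at transient receptor potential cation channel subfamily V member 1 (Homo sapiens), read by FLIPR; a higher number here means a weaker inhibitor, a lower number a stronger inhibitor. Compound 1 `CC(C)(C)c1ccc(NC(=O)c2ccc(-c3ncccc3F)cc2)cc1` gives 3 nM. For the measured compounds named here, compound 2 `CC(C)(C)c1ccc(NC(=O)c2ccc(-c3ncccc3N(S(C)(=O)=O)S(C)(=O)=O)cc2)cc1` gives 0.8 nM, the lowest of the two numbers; the only step between them, a 3.8-fold lower number from compound 1 to compound 2 (0.57 log units; beyond the scatter), is modest. Compound 3 `CN(C)Cc1cccnc1-c1ccc(C(=O)Nc2ccc(C(C)(C)C)cc2)cc1` differs from compound 2 in one place: (dimethylamino)methyl in place of bis(methylsulfonyl)amino on an aromatic carbon. Going by the values given here, no measured step covers this exact change; the step from compound 1 to compound 2 only shows that this position has so far accepted two quite different groups. The change is therefore expected to give a 3.8-fold higher number from compound 2 to compound 3 (0.57 log units; beyond the scatter), a small shift at most. Compound 3 is estimated at 3 nM, between 0.8 nM and 12 nM.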

Compound 3, half-maximal inhibitory concentration in the transient receptor potential cation channel subfamily V member 1 assay: 746 nM
Estimate against measurement, compound 3: 250-fold (2.40 log units) below; the whole stated range lies below it.
By their numbers in the transient receptor potential cation channel subfamily V member 1 assay, from the lowest: compound 2; then compound 1; then compound 3.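

In the transient receptor potential cation channel subfamily V member 1 assay, this position proves far less forgiving than compound 1 and compound 2 suggested: the (dimethylamino)methyl group gives a 930-fold higher number from compound 2 to compound 3 (2.97 log units; beyond the scatter) and a 250-fold higher number from compound 1 to compound 3 (2.40 log units; beyond the scatter). In a physicochemical assay for solubility, at pH 7.4 (on this read-out higher numbers stand for higher solubility and lower numbers for lower solubility), compound 2 gives 1 ug/mL and compound 3 gives 50 ug/mL. The same change moves the physicochemical assay the other way, so the large loss of inhibition comes with a real gain in solubility: the measured solubility of compound 2, 1 ug/mL, and of compound 3, 50 ug/mL, a 50-fold higher number (1.70 log units; beyond the scatter)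

Going by these compounds, what remains open is whether any group on this aromatic carbon can keep both. The data do not separate the dimethylamino part from the change as a whole. An aminomethyl or a hydroxymethyl group here could test that.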